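This account rests on a few compounds, and the source may have more. Where it says the series, first, only, none or still open, it means among the compounds named here.

Working notes on the aryl variation at the carbon with a double bond to nitrogen, on the shared core of compound 1 `CN(C)CCn1cnnc1-c1cc(Oc2ccc(NC(=O)N/N=C/c3c(Cl)cccc3Cl)cc2F)ccn1`. In a functional assay on U-87MG ATCC cells (Homo sapiens) for cytotoxicity, read by MTT assay, with a stated time of 72 h (a lower number here means a stronger inhibitor, a higher number a weaker inhibitor), compound 1 returns only a limit, > 100000 nM. Going by the values given here, compound 2 `CN(C)CCn1cnnc1-c1cc(Oc2ccc(NC(=O)N/N=C/c3ccc(F)cc3)cc2F)ccn1` carries 4-fluorophenyl there, and in this assay compound 2 gives 2310 nM, the only numeric value in the set; the change is an at least 43-fold lower number from compound 1 to compound 2 (1.63 log units; beyond the scatter). Compound 3 `CN(C)CCn1cnnc1-c1cc(Oc2ccc(NC(=O)N/N=C/c3ccc(O)c(O)c3)cc2F)ccn1` carries 3,4-dihydroxyphenyl. In this assay compound 3 likewise returns a limit, > 100000 nM. Relative to compound 2 this is an at least 43-fold higher number from compound 2 to compound 3 (1.63 log units; beyond the scatter), while a step that the two limits leave unreadable from compound 1 to compound 3. Compound 3 therefore stands at the limit of > 100000 nM in this assay, at which 2 of the 3 values shown sit, with nothing in the set measured weaker.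

Compound 4 `CN(C)CCn1cnnc1-c1cc(Oc2ccc(NC(=O)N/N=C/c3cccc(Cl)c3Cl)cc2F)ccn1` differs from compound 3 by 2,3-dichlorophenyl in place of 3,4-dihydroxyphenyl on a carbon with a double bond to nitrogen. Among the compounds with values here, two measured steps bear on it. Leaving 3,4-dihydroxyphenyl reverses the direction of an at least 43-fold higher number from compound 2 to compound 3 (1.63 log units; beyond the scatter), which leaves room for a large lowering. Entering a dichlorophenyl recalls an at least 43-fold lower number from compound 1 to compound 2 (1.63 log units; beyond the scatter), where a different dichlorophenyl sat at the limit; no measured pair separates the two chlorine patterns. A large lowering in this assay is expected, but short of compound 2. Compound 4 is estimated at 12000 nM, in the range 2500 nM to 100000 nM. That estimate means an at least 8.3-fold lower number from compound 3 to compound 4 (0.92 log units; beyond the scatter) is expected.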

Compound 4, half-maximal inhibitory concentration: 13200 nM
Estimate against measurement, compound 4: 1.1-fold (0.04 log units) below, within the range that was stated.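

Going by these compounds alone, compound 4 gives the first reading in this assay that separates two chlorine patterns at this carbon with a double bond to nitrogen: an at least 7.5-fold lower number from compound 1 to compound 4 (0.87 log units; beyond the scatter), so a dichlorophenyl here is not tied to the limit, and the pattern of the chlorines changes the read-out. The change from two hydroxyl groups to two chlorines on the same phenyl ring also moves the series away from the limit, an at least 7.5-fold lower number from compound 3 to compound 4 (0.87 log units; beyond the scatter), which shows that a 3,4-dihydroxyphenyl and a dichlorophenyl need not behave alike at this place. Against the singly substituted ring, 2,3-dichlorophenyl still falls short, a 5.7-fold higher number from compound 2 to compound 4 (0.76 log units; beyond the scatter), so compound 2 remains the strongest inhibitor of the four, with every step to it beyond the scatter.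

As far as these compounds go, compound 1 and compound 3 each remain a limit and not a number, so the true size of their steps and any order between them stay unknown: the limit of > 100000 nM in this assay, at which 2 of the 4 values shown sit. Also open, from the compounds shown here alone, is how a single chlorine, a methoxy group or an amine on the phenyl ring would read at this place, and whether any such group would pass compound 2.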